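Swapping the amide substituent on a pyrazole EP1 ligand

The source may report more compounds than this note shows. Statements on the series, on what has been measured and on what is new or still open speak of the compounds shown alone.

Compounds measured in an assay on CHO-K1 cells for displacement of a labelled ligand from prostaglandin E2 receptor EP1 subtype (Homo sapiens); on this read-out higher numbers stand for weaker inhibition and lower numbers for stronger inhibition:
- Compound 1 `Cc1cc(C(=O)Nc2c(F)cccc2F)nn1Cc1cc(Cl)ccc1OCc1ccccc1` gives 10 nM
- Compound 2 `Cc1cc(C(N)=O)nn1Cc1cc(Cl)ccc1OCC(C)C` gives 126 nM
- Compound 3 `Cc1cc(NC(=O)C2CCCC2)nn1Cc1cc(Cl)ccc1OCc1ccccc1` gives 15.9 nM

Compound 1 has the lowest number of the three. Compound 3 is closest to it, as the step of a 1.6-fold higher number from compound 1 to compound 3 (0.20 log units; within the scatter) is within the scatter, while compound 2 lies well beyond it.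

Compound 4 `Cc1cc(NC(=O)CC2CCCCC2)nn1Cc1cc(Cl)ccc1OCc1ccccc1` differs from compound 1 as follows: ((cyclohexylmethyl)carbonyl)amino in place of (2,6-difluorophenyl)carbamoyl on an aromatic carbon.

Going by the values given here, only one measured step bears on this change: the step of a 1.6-fold higher number from compound 1 to compound 3 (0.20 log units; within the scatter), in which a saturated ring also replaced the difluorophenyl group, and it stayed within the scatter. A similar outcome is expected here, so the step of a 2.0-fold higher number from compound 1 to compound 4 (0.30 log units; within the scatter) is estimated to stay within the scatter. Compound 4 is therefore expected to give 20 nM, in the range 7 nM to 60 nM.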

Compound 4, half-maximal inhibitory concentration: 6.31 nM
Estimate against measurement, compound 4: 3.2-fold (0.50 log units) above; the whole stated range lies above it.
By their numbers in this assay, from the lowest: compounds 4, 1 and 3 (each within the scatter of the next, the first and the last beyond it); then compound 2.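

Measured in this assay, ((cyclohexylmethyl)carbonyl)amino can stand in for (2,6-difluorophenyl)carbamoyl at this position, with a 1.6-fold lower number from compound 1 to compound 4 (0.20 log units; within the scatter) and no aromatic ring in the entering group. Within the saturated amides, cyclohexylmethyl in place of cyclopentyl on the carbonyl carbon gives a 2.5-fold lower number from compound 3 to compound 4 (0.40 log units; beyond the scatter), a modest step but one beyond the scatter. No measurement shown gives a reason for this step.

Open, from the compounds shown here alone, is whether a straight hexyl chain in place of cyclohexylmethyl would keep the number this low. Also open, going by these compounds, is how a carboxylic acid or an amine on the cyclohexyl ring would fare.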